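From carbonyl to sulfonyl at an assay limit

A few compounds are considered here, and "the series" means these few. Any claim that something is new, unique, unknown or untested is made for them only; others in the source may bear on it.

Measured in an ADME assay on H9c2 cells (Rattus norvegicus) for cytotoxicity; a lower number here means a stronger inhibitor, a higher number a weaker inhibitor:
- compound 1 `CCOc1ccc2nc(NC(=O)C3CC3)sc2c1`: > 50000 nM (a limit)
- compound 2 `Cc1ccc2nc(NC(=O)C3CC3)sc2c1`: > 50000 nM (a limit)
- compound 3 `O=C(Nc1nc2ccc(C(F)(F)F)cc2s1)C1CC1`: > 50000 nM (a limit)

In this assay, compound 3 stands at > 50000 nM, which is a limit and not a number. The two other values are also limits. Compound 4 `O=S(=O)(Nc1nc2ccc(C(F)(F)F)cc2s1)C1CC1` carries cyclopropylsulfonyl in place of cyclopropylcarbonyl on a nitrogen on an aromatic ring. The measured steps all concern a group on an aromatic carbon, and none concerns this nitrogen: a step that the two limits leave unreadable from compound 1 to compound 2, a step that the two limits leave unreadable from compound 1 to compound 3 and a step that the two limits leave unreadable from compound 2 to compound 3. They give no size to carry over. Among the compounds with values here, the only guide for compound 3 and its neighbours is the limit of > 50000 nM in this assay, at which 3 of the 3 values shown sit. No step beyond the scatter is therefore expected, in either direction, and another limit is likely. The expected change is a number no higher from compound 3 to compound 4 (the limit leaves the size open). Compound 4 is estimated at 50000 nM, with an expected range of 20000 nM to 100000 nM.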

Compound 4, half-maximal inhibitory concentration: 6600 nM
Compound 4: middle estimate off by 7.6-fold (0.88 log units), on the high side; the whole stated range lies above it.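

In this assay, the nitrogen on an aromatic ring proves to be a place where the read-out responds: cyclopropylsulfonyl in place of cyclopropylcarbonyl gives an at least 7.5-fold lower number from compound 3 to compound 4 (0.87 log units; beyond the scatter). The steps among compound 1, compound 2 and compound 3, all on an aromatic carbon, cannot be read, and compound 4 alone gives a number rather than a limit: the limit of > 50000 nM in this assay, at which 3 of the 4 values shown sit.

Going by these compounds, it remains open whether the same change would read alike with ethoxy or methyl on the aromatic carbon. On these data alone, how a longer chain in place of the cyclopropyl ring on the sulfonyl would read also remains open.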